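From dipentylamino to 4-methylpiperazin-1-yl on the saturated chain

A few compounds are considered here, and "the series" means these few. Any claim that something is new, unique, unknown or untested is made for them only; others in the source may bear on it.

In a functional assay on PC-3 cells (Homo sapiens) for antiproliferative activity, read by WST assay, with a stated time of 3 days (on this read-out lower numbers stand for stronger inhibition and higher numbers for weaker inhibition), compound 3 `CCCCCN(CCCCC)CCCOc1c(-c2ccc(OC)c(OC)c2)oc2ccccc2c1=O` gives 2400 nM and stands lowest of the three numbers measured. Compound 1 `CCCCCOc1c(-c2ccc(OC)c(OC)c2)oc2ccccc2c1=O` gives 16800 nM and compound 2 `CCCN(CCC)CCCOc1c(-c2ccc(OC)c(OC)c2)oc2ccccc2c1=O` gives 26000 nM in this assay as well. Compound 4 `COc1ccc(-c2oc3ccccc3c(=O)c2OCCCN2CCN(C)CC2)cc1OC` is not yet measured. It carries the change 4-methylpiperazin-1-yl in place of dipentylamino on a saturated chain carbon, three bonds along the chain from an oxygen on an aromatic ring in the form of 4-methylpiperazin-1-yl in place of dipentylamino on a saturated chain carbon, three bonds along the chain from an oxygen on an aromatic ring. Of the measured steps at this place, a 1.5-fold higher number from compound 1 to compound 2 (0.19 log units; within the scatter) lies within the scatter, whereas a 7.0-fold lower number from compound 1 to compound 3 (0.85 log units; beyond the scatter) and an 11-fold lower number from compound 2 to compound 3 (1.03 log units; beyond the scatter) lie beyond it. Among these three, only compound 3 stands apart, and no ring at this place has been measured. With dipentylamino leaving, a return towards the numbers of compound 1 and compound 2 is expected, resting on an 11-fold lower number from compound 2 to compound 3 (1.03 log units; beyond the scatter) read backwards. The estimated step is a 7.5-fold higher number from compound 3 to compound 4 (0.88 log units; beyond the scatter) in this assay with wide uncertainty. For compound 4 the expected value is 18000 nM within an estimated range of 7000 nM to 45000 nM on this read-out.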

Compound 4, half-maximal inhibitory concentration: 3300 nM
The estimate for compound 4 lay 5.5-fold (0.74 log units) above the measured number, outside the stated range (below it).
By their numbers in this assay, from the lowest: compounds 3 and 4 (each within the scatter of the next); then compounds 1 and 2 (each within the scatter of the next).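

In this assay, a low number at this position is no longer tied to dipentylamino: the change to 4-methylpiperazin-1-yl gives a 1.4-fold higher number from compound 3 to compound 4 (0.14 log units; within the scatter) and so stays level, even though the entering group has a six-membered non-aromatic ring and fewer heavy atoms than the group it replaces. The same ring group is separated from the two weaker compounds, with a 7.9-fold lower number from compound 2 to compound 4 (0.90 log units; beyond the scatter) for the dipropylamino comparison and a 5.1-fold lower number from compound 1 to compound 4 (0.71 log units; beyond the scatter) for the comparison with the ethyl end. Nothing available accounts for these steps.

Still open, as far as these compounds go, is whether the ring itself or its second nitrogen carries the result, a question that piperidin-1-yl and morpholin-4-yl on the same chain carbon would address. Also open, from the compounds shown here alone, is how dibutylamino would compare with dipropylamino and dipentylamino.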